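The compounds below may be only part of what the source reports. "The series", "measured", "known", "first", "only" and "open" are said of these compounds alone.

Compound 2 `Cc1ccc(CN2CCC(Cn3c(=O)oc4ccccc43)CC2)cc1` has the lower of the two numbers measured in an assay on membranes from liver for displacement of a labelled ligand from Sigma non-opioid intracellular receptor 1 (Rattus norvegicus); on this read-out lower numbers stand for stronger inhibition and higher numbers for weaker inhibition: compound 2 gives 2.9 nM, while compound 1 `O=c1oc2ccccc2n1CC1CCN(Cc2ccccc2Cl)CC1` gives 61 nM. Going by the values given here, the single measured step, a 21-fold lower number from compound 1 to compound 2 (1.32 log units; beyond the scatter), is the only guide available. Compound 3 `Cc1cc(C)c(CN2CCC(Cn3c(=O)oc4ccccc43)CC2)c(C)c1` arises from compound 2 by the change (2,4,6-trimethylphenyl in place of 4-methylphenyl on a saturated chain carbon bound to an amine nitrogen in a ring). Among the compounds with values here, no measured pair shows this exact change; the one known step only shows that the choice of group on the aromatic ring in that place can move the number a great deal, and in that case it fell. Within the data shown here, with no closer precedent, the expectation is a modest step of a 1.7-fold higher number from compound 2 to compound 3 (0.24 log units; within the scatter), leaning toward a somewhat higher number for compound 3 than for compound 2. On that basis compound 3 is estimated at 5 nM in this assay, with a range from 1.5 nM to 20 nM.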

Compound 3, inhibition constant: 6230 nM
Beside the measured number, compound 3's estimate is 1200-fold (3.10 log units) below it; measured number outside the range, above it.
By their numbers in this assay, from the lowest: compound 2; then compound 1; then compound 3.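

In this assay, going from 4-methylphenyl to 2,4,6-trimethylphenyl on a saturated chain carbon bound to an amine nitrogen in a ring gives a 2100-fold higher number from compound 2 to compound 3 (3.33 log units; beyond the scatter), so a gain of only two carbon atoms can nearly abolish the inhibition seen with compound 2. The 2-chlorophenyl group also does far better than the 2,4,6-trimethylphenyl group, with a 100-fold higher number from compound 1 to compound 3 (2.01 log units; beyond the scatter), which places compound 3 clearly last of the three and shows that this position tolerates some aromatic groups much less than others. No supporting measurement is available to explain this sharp drop.

The compounds shown leave open whether all three methyl groups are needed for the loss, which a dimethylphenyl group could help settle. They also leave open how an unsubstituted phenyl or a cyclohexyl group would behave in this place.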